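The source may hold more compounds than are shown below. What is called first, only, known or untested is meant among the compounds shown, and "the series" means these compounds.

Working notes on the series in an assay on isolated protein with Bile acid receptor (Homo sapiens) as the target; a higher number here means that more compound is needed for the effect, a lower number that less compound is needed.

Going by the values given here, compound 1 `COC(=O)/C=C/c1cccc(N(Cc2ccc(/C=C/c3ccccc3F)cc2)C(=O)C2CCCCC2)c1` gives 64 nM in this assay, the lowest of the three numbers so far. Compound 2 `COC(=O)/C=C/c1cccc(N(Cc2ccc(/C=C/c3ccccc3F)cc2)C(=O)NC(C)C)c1` gives 431 nM; the step of a 6.7-fold higher number from compound 1 to compound 2 (0.83 log units; beyond the scatter) shows that a change at the carbonyl carbon costs potency. Compound 3 `COC(=O)/C=C/c1cccc(N(Cc2ccc(/C=C/c3ccccn3)cc2)C(=O)C(C)C)c1` gives 310 nM; it differs from compound 1 in more than one place, so only the two values themselves can be compared, and compound 3 sits above compound 1 by more than the scatter.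

Compound 4 `COC(=O)/C=C/c1cccc(N(Cc2ccc(-c3ccc(F)c(F)c3)cc2)C(=O)C2CCCCC2)c1` carries the change (3,4-difluorophenyl in place of 2-(2-fluorophenyl)ethenyl on an aromatic carbon). Among the compounds with values here, no measured step touches this part of the core of compound 1: the step from compound 1 to compound 2 and the values of compound 3 concern other positions, so they give no direct guide. With nothing to anchor the change, compound 4 is expected to stay near compound 1 or lose somewhat, a step of about a 2.3-fold higher number from compound 1 to compound 4 (0.37 log units; beyond the scatter). The estimate for compound 4 in this assay is 150 nM, with a range from 40 nM to 600 nM.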

Compound 4, half-maximal effective concentration: 72 nM
Beside the measured number, compound 4's estimate is 2.1-fold (0.32 log units) above it; the range from low to high includes it.
By their numbers in this assay, from the lowest: compounds 1 and 4 (each within the scatter of the next); then compounds 3 and 2 (each within the scatter of the next).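

In this assay, the step of a 1.1-fold higher number from compound 1 to compound 4 (0.05 log units; within the scatter) shows that this position, on an aromatic carbon para to a large group, accepts 3,4-difluorophenyl in place of 2-(2-fluorophenyl)ethenyl without a difference that can be read. In this one pair, the double bond outside aromatic rings is therefore not required for a value in this range, although the swap also alters the fluorine pattern, so the pair cannot separate the two changes. Nothing measured here bears on why the two values agree.

From the compounds shown here alone, it remains open whether the fluorines matter at all, as a plain phenyl group or a phenyl ring carrying a carboxylic acid or an amine would test. Going by these compounds, it is also open whether the step seen with isopropylamino at the carbonyl carbon carries over to the 3,4-difluorophenyl series.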